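The source may report more compounds than this note shows. Statements on the series, on what has been measured and on what is new or still open speak of the compounds shown alone.

Measured so far, in a physicochemical assay for lipophilicity, using the shake flask method; a lower number here means a more polar compound, a higher number a more lipophilic compound:
compound 1, `Nc1ncnc(Oc2ccc(NC(=O)C3(C(=O)Nc4ccc(F)cc4)CC3)cc2F)c1/C=N/O`: 2.62
compound 2, `CCOC(=O)CO/N=C/c1c(N)ncnc1Oc1ccc(NC(=O)C2(C(=O)Nc3ccc(F)cc3)CC2)cc1F`: 3.15
compound 3, `Nc1ncnc(Oc2ccc(NC(=O)C3(C(=O)Nc4ccc(F)cc4)CC3)cc2F)c1/C=N/OC1CCCCC1`: 4.69

Compound 3 stands highest of the three in this assay; its nearest neighbour is compound 2, and compound 1 lies furthest below it. The measured steps all run toward compound 3: a number 2.07 log units higher from compound 1 to compound 3 (beyond the scatter) and a number 1.54 log units higher from compound 2 to compound 3 (beyond the scatter), both large, while a number 0.53 log units higher from compound 1 to compound 2 (beyond the scatter) is modest.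

Compound 4, `Nc1ncnc(Oc2ccc(NC(=O)C3(C(=O)Nc4ccc(F)cc4)CC3)cc2F)c1/C=N/OC1CCCC1`, differs from compound 3 in one place: cyclopentyl in place of cyclohexyl on an oxygen. For the measured compounds named here, no measured step removes a single carbon from a ring on this oxygen; the two steps that end at compound 3 only show that the cyclohexyl substituent on that oxygen carries the series to its highest number, and that the step from hydrogen to cyclohexyl is a good deal larger than the step from hydrogen to the (ethoxycarbonyl)methyl group. Going from cyclohexyl to cyclopentyl is a smaller change than either, so a small step downward is expected in this assay, a number 0.44 log units lower from compound 3 to compound 4 (beyond the scatter), close to the scatter but probably somewhat beyond it.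

For compound 4 the expected value is 4.25, with a range from 3.85 to 4.65.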

Compound 4, partition coefficient: 4.27
Beside the measured number, compound 4's estimate is 0.02 log units below it; low and high end bracket the measured number.
By their numbers in this assay, from the lowest: compound 1; then compound 2; then compound 4; then compound 3.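

In this assay, for the compounds shown here, the change from a six-membered to a five-membered ring of carbon on the oxygen gives a number 0.42 log units lower from compound 3 to compound 4 (beyond the scatter), the first step in this set that compares two carbon rings at this position. The cyclopentyl group still keeps most of the rise seen with cyclohexyl, with a number 1.65 log units higher from compound 1 to compound 4 (beyond the scatter) and a number 1.12 log units higher from compound 2 to compound 4 (beyond the scatter), so both rings stand clearly above hydrogen and the (ethoxycarbonyl)methyl group at this position. Nothing at hand gives a reason for the size of these steps.

On these data alone, two rings do not establish a trend with ring size, so it remains open whether cyclobutyl or cycloheptyl on this oxygen would extend the order seen with cyclopentyl and cyclohexyl. Also open, as far as these compounds go, is how this assay would read for an open-chain group such as isopropyl, for a ring holding an amine such as piperidinyl, or for a carboxylic acid in place of the ethyl ester of the (ethoxycarbonyl)methyl group.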